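This account rests on a few compounds, and the source may have more. Where it says the series, first, only, none or still open, it means among the compounds named here.

In a physicochemical assay for solubility, in phosphate buffer, at pH 7.4 (on this read-out higher numbers stand for higher solubility and lower numbers for lower solubility), compound 1 `CCOC(=O)c1c(-c2ccc(OC)cc2)[nH]c2cccc(OC)c2c1=O` reads > 100000 nM, which is a limit of the assay and not a number. Compound 2 `CCOC(=O)c1c(-c2ccc(OC)cc2)[nH]c2cc(OC)ccc2c1=O`, which keeps the 4-methoxyphenyl group on a core of its own, gives a measured 8000 nM. Compound 3 `CCOC(=O)c1c(-c2ccc(Cl)c(Cl)c2)[nH]c2cccc(OC)c2c1=O` is still unmeasured. It carries 3,4-dichlorophenyl in place of 4-methoxyphenyl on an aromatic carbon, next to the ring nitrogen and ortho to an ethoxycarbonyl group (3,4-dichlorophenyl in place of 4-methoxyphenyl on an aromatic carbon). Within the data shown here, no measured pair covers this exchange, so the size of the step rests on judgement alone. A downward step in this assay is expected, clearly beyond the scatter of repeated measurements. The expected change is an at least 6.6-fold lower number from compound 1 to compound 3 (0.82 log units; beyond the scatter). For compound 3 the estimated value is 15000 nM, with an expected range from 2000 nM to 80000 nM.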

Compound 3, solubility: 39000 nM
For compound 3 the middle estimate is 2.6-fold (0.41 log units) below the measured one, and the stated range covers the measured number.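

In this assay, 3,4-dichlorophenyl in place of 4-methoxyphenyl on the aromatic carbon next to the ring nitrogen gives an at least 2.5-fold lower number from compound 1 to compound 3 (0.40 log units; beyond the scatter). Among these compounds, this is the first reading of any change at this position, and it shows that the number here depends on the aryl group, with compound 3 giving a measured value on the shared core. The step can be stated only as a lower bound because compound 1 stands at a limit of this assay: the limit of > 100000 nM in this assay, at which 1 of the 3 values shown sits.

Among the compounds shown here, only two aryl groups appear at this position, so the effect of a 4-chlorophenyl group, or of a phenyl ring carrying an amine or a carboxylic acid, remains open. Also open, as far as these compounds go, is whether the same exchange on the core of compound 2 would give a step of similar size.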